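Cytotoxicity notes: from cyclopentylamino to pentyloxy

The compounds below may be only part of what the source reports. "The series", "measured", "known", "first", "only" and "open" are said of these compounds alone.

Measured so far in an ADME assay on MOLT-3 cells (Homo sapiens) for cytotoxicity, with a stated time of 7 days; a higher number here means that more compound is tolerated, a lower number that less compound is tolerated:
- compound 1 `CC(C)CSc1nc(N)nc2c1ncn2/C=C1/CC1(CO)CO` gives "not determined" (no result reported)
- compound 2 `CN(C)c1nc(N)nc2c1ncn2/C=C1/CC1(CO)CO` gives "not determined" (no result reported)
- compound 3 `Nc1nc(NC2CCCC2)c2ncn(/C=C3/CC3(CO)CO)c2n1` gives > 20000 nM

For the measured compounds named here, compound 3 is the only compound here with a reported result, and its > 20000 nM is a limit of the assay, not a number. Going by the values given here, compound 1 and compound 2 add no result, so no measured step exists within this set.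

The next compound is compound 4 `CCCCCOc1nc(N)nc2c1ncn2/C=C1/CC1(CO)CO`, which carries pentyloxy in place of cyclopentylamino on an aromatic carbon. The five-membered non-aromatic ring of carbon only leaves with this change, and the group that enters has no ring.

Among the compounds with values here, with no measured step to size the change, the expectation for this assay rests on compound 3 alone. The expected step is small, with no shift beyond the usual scatter and only a slight lean towards less compound being tolerated. In numbers, the estimate is an at least 1.1-fold lower number from compound 3 to compound 4 (0.04 log units; that floor lies within the scatter), though it is anchored to a limit. The estimate for compound 4 is 18000 nM, with an expected range from 6000 nM to 40000 nM. A report of a limit alone would also be no surprise for compound 4.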

Compound 4, half-maximal cytotoxic concentration: > 20000 nM
Compound 4 ended at the assay's limit (the forecaster's own chance of this, stated with the estimate: 55%); at least 1.1-fold (0.04 log units) between middle value and limit.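

Compound 3 and compound 4 both end at a limit in this assay, not at a number, and no step between them can be read: the limit of > 20000 nM in this assay, at which 2 of the 4 values shown sit.

Still open, going by these compounds, is how much of either compound this assay would tolerate beyond that limit, and whether pentyloxy in place of cyclopentylamino on an aromatic carbon makes any difference.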